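The source may report more compounds than this note shows. Statements on the series, on what has been measured and on what is new or still open speak of the compounds shown alone.

Measured compounds:
compound 1 `N#CC1=C(N)Oc2c(c3nc4ccccc4nc3c3ccccc23)C12C(=O)N(Cc1cnnn1-c1ccc(Cl)c(Cl)c1)c1ccccc12` — > 50000 nM
compound 2 `CC(=O)Nc1ccc(-n2nncc2CN2C(=O)C3(C(C#N)=C(N)Oc4c(N)cc5nc6ccccc6nc5c43)c3ccccc32)cc1` — > 50000 nM

In a functional assay on HepG2 cells (Homo sapiens) for antiproliferative activity, read by MTT assay, with a stated time of 48 h (on this read-out higher numbers stand for weaker inhibition and lower numbers for stronger inhibition), compound 1 gives > 50000 nM, which is a limit of the assay rather than a number. In this assay compound 2 likewise gives > 50000 nM, also a limit. Compound 2 thus stands at the upper limit, as does compound 1 (the limit of > 50000 nM in this assay, at which 2 of the 2 values shown sit). Compound 3 `Cc1ccc(Cl)cc1-n1nncc1CN1C(=O)C2(C(C#N)=C(N)Oc3c(N)cc4nc5ccccc5nc4c32)c2ccccc21` has not been measured; it differs from compound 2 by 5-chloro-2-methylphenyl in place of 4-acetamidophenyl on an aromatic nitrogen. With both measured compounds sitting at the limit, no step is expected beyond the scatter: the step is estimated as a step that the limit leaves unreadable from compound 2 to compound 3. Compound 3 is expected to give about 60000 nM, between 20000 nM and 200000 nM.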

Compound 3, half-maximal inhibitory concentration: 17300 nM
Beside the measured number, compound 3's estimate is 3.5-fold (0.54 log units) above it; the measured number lies below the stated range.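

Replacing 4-acetamidophenyl with 5-chloro-2-methylphenyl on the aromatic nitrogen gives, in this assay, an at least 2.8-fold lower number from compound 2 to compound 3 (0.46 log units; beyond the scatter). From the compounds shown here alone, this shows that a change at this position can bring a compound off the limit, which the earlier values could not show: the limit of > 50000 nM in this assay, at which 2 of the 3 values shown sit. Compound 2 has only a limit, so the full size of the step stays unknown.

Going by these compounds, it remains open whether losing the acetamide or gaining the chlorine and methyl matters more. On these data alone, how an amine or a carboxylic acid on this phenyl ring would read also remains open.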